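A Solubility Estimate for Compound 4

The compounds below may be only part of what the source reports. "The series", "measured", "known", "first", "only" and "open" are said of these compounds alone.

Compound 1, `O=C1O[C@@H](CN2CCC(c3ccc(F)cc3)CC2)CN1c1ccc(-n2cc(-c3ccccn3)cn2)c(F)c1`, gives in a physicochemical assay for solubility, read by HPLC, with a stated time of 24 h (a lower number here means a less soluble compound, a higher number a more soluble compound), a value that is a limit of the assay, <= 19400 nM.
Compound 2, `O=C(OC[C@H]1CN(c2ccc(-n3cc(-c4ccccn4)cn3)c(F)c2)C(=O)O1)c1ccccc1`, gives in this assay a value that is also a limit, <= 65400 nM.
Compound 3, `COC[C@H]1CN(c2ccc(-n3cc(-c4ccccn4)cn3)c(F)c2)C(=O)O1`, gives in this assay 36200 nM.

Compound 3 therefore holds the only actual number of the three; the other two readings stop at a limit, as shown by the limit of <= 19400 nM in this assay, at which 1 of the 3 values shown sits, and (the limit of <= 65400 nM in this assay, at which 1 of the 3 values shown sits). Within the data shown here, the one step between measured neighbours, a step that the limit leaves unreadable from compound 2 to compound 3, cannot be sized for the same reason.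

Compound 4, `O=C(NC[C@H]1CN(c2ccc(-n3cc(-c4ccccn4)cn3)c(F)c2)C(=O)O1)C(F)F`, differs from compound 3 by ((difluoromethyl)carbonyl)amino in place of methoxy on a saturated chain carbon bound to a saturated ring carbon. Among the measured compounds shown here, no measured step bears on this change, since the only step recorded is unreadable and involves a different group. Compound 4 is thus expected to sit close to compound 3, with an estimated step of a 1.1-fold higher number from compound 3 to compound 4 (0.04 log units; within the scatter) that may fall within the scatter. The expected reading for compound 4 in this assay is 40000 nM, with a range from 10000 nM to 150000 nM.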

Compound 4, solubility: 29900 nM
For compound 4 the middle estimate is 1.3-fold (0.13 log units) above the measured one; the measured number falls inside the stated range.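

Among these compounds, at the saturated chain carbon bound to a saturated ring carbon, the first readable step in this assay is a 1.2-fold lower number from compound 3 to compound 4 (0.08 log units; within the scatter) and so ((difluoromethyl)carbonyl)amino, which carries a hydrogen-bond donor that methoxy lacks, can stand in place of methoxy without a change beyond the scatter. Compound 2 gives a limit of <= 65400 nM and the step from compound 2 to compound 4 cannot be read. Nothing measured here offers an explanation for this reading.

The compounds shown leave open how this assay would read with an amine or a carboxylic acid on this same carbon, or with a longer chain in place of the difluoromethyl. They also leave open whether a plain acetylamino group would read like compound 4.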